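Pyridyl for propargyl ether: expected clearance shift

The source may hold more compounds than are shown below. What is called first, only, known or untested is meant among the compounds shown, and "the series" means these compounds.

Working notes on the series. Three compounds share one core: compound 1 is `Nc1ccc(S(=O)(=O)N2CCN(c3ncc(C(O)(C(F)(F)F)C(F)(F)F)cc3C#CCO)CC2)cn1`, compound 2 is `COCC#Cc1cc(C(O)(C(F)(F)F)C(F)(F)F)cnc1N1CCN(S(=O)(=O)c2ccc(N)nc2)CC1` and compound 3 is `CS(=O)(=O)c1ccc(-c2cc(C(O)(C(F)(F)F)C(F)(F)F)cnc2N2CCN(S(=O)(=O)c3ccc(N)nc3)CC2)cc1`. In an ADME assay (liver) for metabolic stability, with Liver microsome (Homo sapiens) as the target, using microsomes and NADPH, with a stated time of 30 min, tested at 1 uM (a higher number here means faster removal of the compound, a lower number slower removal), compound 1 gives only a limit of the assay, < 14 mL.min-1.g-1. In this assay compound 2 gives 15 mL.min-1.g-1. In this assay compound 3 gives 32 mL.min-1.g-1. Among the two actual numbers compound 2 stands lowest, with compound 3 nearest, a 2.1-fold higher number from compound 2 to compound 3 (0.33 log units; beyond the scatter). The comparison from compound 1 points the same way, an at least 2.2-fold higher number from compound 1 to compound 3 (0.35 log units; beyond the scatter), whereas an at least 1.0-fold higher number from compound 1 to compound 2 (0.02 log units; that floor lies within the scatter) sits on the limit of < 14 mL.min-1.g-1 in this assay, at which 1 of the 3 values shown sits, and cannot separate the pair.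

Compound 4 is `Nc1ccc(S(=O)(=O)N2CCN(c3ncc(C(O)(C(F)(F)F)C(F)(F)F)cc3-c3cnccc3F)CC2)cn1` and is not yet measured. Its change from compound 2 is 4-fluoropyridin-3-yl in place of 3-methoxyprop-1-yn-1-yl on an aromatic carbon. For the measured compounds named here, the measured step that bears on it is the one that likewise exchanges the 3-methoxyprop-1-yn-1-yl group for a six-membered aromatic ring, a 2.1-fold higher number from compound 2 to compound 3 (0.33 log units; beyond the scatter), and the comparison an at least 2.2-fold higher number from compound 1 to compound 3 (0.35 log units; beyond the scatter) agrees in direction and size. An upward step of comparable size is therefore expected for compound 4, a 1.9-fold higher number from compound 2 to compound 4 (0.27 log units; within the scatter). In this assay compound 4 is estimated at 28 mL.min-1.g-1, with a range from 15 mL.min-1.g-1 to 52 mL.min-1.g-1.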

Compound 4, intrinsic clearance in microsomes: 17 mL.min-1.g-1
For compound 4 the middle estimate is 1.6-fold (0.22 log units) above the measured one; low and high end bracket the measured number.
By their numbers in this assay, from the lowest: compounds 2, 4 and 3 (each within the scatter of the next, the first and the last beyond it). At a limit, below all of these: compound 1.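

In this assay on an aromatic carbon ortho to a large group, 4-fluoropyridin-3-yl in place of 3-methoxyprop-1-yn-1-yl gives a 1.1-fold higher number from compound 2 to compound 4 (0.05 log units; within the scatter) and so a six-membered aromatic ring does not by itself separate a compound from the 3-methoxyprop-1-yn-1-yl compound. The exchange of 4-(methylsulfonyl)phenyl for 4-fluoropyridin-3-yl also stays inside the usual scatter, with a 1.9-fold lower number from compound 3 to compound 4 (0.27 log units; within the scatter). For the compounds shown here, compound 3 had been the only ring example, and its step from compound 2 lay beyond the scatter, so that step can no longer be read as belonging to aromatic rings at this position in general, although compound 4 cannot be separated from either neighbour.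

Compound 1 gives only a limit of the assay, and an at least 1.2-fold higher number from compound 1 to compound 4 (0.08 log units; that floor lies within the scatter) sits on that limit and cannot separate the pair: the limit of < 14 mL.min-1.g-1 in this assay, at which 1 of the 4 values shown sits.

The compounds shown also leave open what an unsubstituted phenyl or a pyridin-3-yl without the fluorine would give here in this assay, and with them how much of the gap between compound 2 and compound 3 goes with the methylsulfonyl group.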